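The compounds below may be only part of what the source reports. "The series", "measured", "known", "first", "only" and "open" are said of these compounds alone.

Compound 1 `Cc1cc(-c2cnc(NCc3c(F)ccc4c3CCO4)c3cn[nH]c(=O)c23)n(C)n1` gives 3 in a physicochemical assay for lipophilicity, using the shake flask method, in phosphate buffer, measured as octanol-water partition, with a stated time of 30 min, at pH 7.4; a lower number here means a more polar compound, a higher number a more lipophilic compound. On the numbers in hand, compound 1 stands second highest of three: compound 2 `O=C1c2ccccc2CN1c1cnc(NCc2c(F)ccc3c2CCO3)n2cnnc12` gives 2.7, within the scatter of compound 1, while compound 3 `CN(c1ccccc1)c1cnc(NCc2c(F)ccc3c2CCO3)n2cnnc12` gives 3.6, beyond it. Among the measured compounds shown here, the only measured step, a number 0.90 log units higher from compound 2 to compound 3 (beyond the scatter), concerns a different site of the shared core and does not bear directly on the change at hand. Compound 4 `Cc1nc(CN(C)C)ccc1-c1cnc(NCc2c(F)ccc3c2CCO3)c2cn[nH]c(=O)c12` differs from compound 1 by 6-((dimethylamino)methyl)-2-methylpyridin-3-yl in place of 1,3-dimethyl-1H-pyrazol-5-yl on an aromatic carbon. For the measured compounds named here, with no measured step to guide the size, the expectation rests on the change itself, and a drop is expected, a number 1.00 log units lower from compound 1 to compound 4 (beyond the scatter). For compound 4 the expected value in this assay is 2, between 1.2 and 2.8.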

Compound 4, distribution coefficient: 2
The estimate for compound 4 equals the measured number at the digits printed; measured number inside the range.
By their numbers in this assay, from the lowest: compound 4; then compounds 2 and 1 (each within the scatter of the next); then compound 3.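

Exchanging the 1,3-dimethyl-1H-pyrazol-5-yl group for a 6-((dimethylamino)methyl)-2-methylpyridin-3-yl group gives, in this assay, a number 1.00 log units lower from compound 1 to compound 4 (beyond the scatter). The number falls although the entering group has more heavy atoms, while the counts of hydrogen-bond donors and acceptors stay the same. No measurement shown here accounts for the drop. The compounds shown leave open how much of the step belongs to the (dimethylamino)methyl chain and how much to the ring that carries it. They also leave open how a morpholine or a carboxylic acid in place of the dimethylamino group would read.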